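Trifluoromethyl to Fluoro: Notes on Compound 3

The source may report more compounds than this note shows. Statements on the series, on what has been measured and on what is new or still open speak of the compounds shown alone.

Among the measured compounds shown here, compound 1, `O=C(O)CCCCCCC(=O)Nc1ccc(C2=C(c3ccc(O)cc3)C3CC(S(=O)(=O)Oc4ccc(C(F)(F)F)cc4)C2O3)cc1`, is the one compound of the set with a numerical result. For the measured compounds named here, in a functional assay on DU-145 cells (Homo sapiens) for inhibition, read by MTT assay, with a stated time of 72 h (a lower number here means a stronger inhibitor, a higher number a weaker inhibitor), compound 1 gives 77000 nM, so it stands as the only measured number in the set. Compound 2, `O=S(=O)(Oc1ccccc1)[C@H]1C[C@H]2O[C@@H]1C(c1ccc(O)cc1)=C2c1ccc(O)cc1`, is the other entry. In this assay compound 2 returns only a limit, > 100000 nM. Going by the values given here, that entry is the limit of > 100000 nM in this assay, at which 1 of the 2 values shown sits, so no step between the two measured compounds can be sized.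

Compound 3, `O=C(O)CCCCCCC(=O)Nc1ccc(C2=C(c3ccc(O)cc3)C3CC(S(=O)(=O)Oc4ccc(F)cc4)C2O3)cc1`, has not yet been measured. It differs from compound 1 in one place: fluoro in place of trifluoromethyl on an aromatic carbon. Among the compounds with values here, no measured step in this set covers a change of this kind, and the change is confined to a single group, so no shift beyond the usual scatter is expected in this assay; a mild drift toward the limit would not be surprising. Compound 3 is expected at 100000 nM, with a range from 40000 nM to 250000 nM, which means an expected step of a 1.3-fold higher number from compound 1 to compound 3 (0.11 log units; within the scatter). Given that compound 1 itself sits at 77000 nM, a reading at the high end of that range remains a real possibility for compound 3.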

Compound 3, half-maximal inhibitory concentration: > 100000 nM
Compound 3: a limit, no number (the forecaster's own chance of this, stated with the estimate: 45%); the middle value lies on the limit itself.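

In this assay compound 3 returns only a limit, > 100000 nM, and not a number. Among the compounds shown here, the change from 4-(trifluoromethyl)phenyl to 4-fluorophenyl gives the first step at this position, an at least 1.2-fold higher number from compound 1 to compound 3 (0.11 log units; that floor lies within the scatter), so only a floor for the step is known and it does not establish a real difference between the two compounds. With fluoro on this aromatic carbon, the reading falls on the same limit as compound 2, leaving the trifluoromethyl compound 1 as the one entry with a number: the limit of > 100000 nM in this assay, at which 2 of the 3 values shown sit.

As far as these compounds go, whether this change moves the reading beyond the scatter stays open, as does the number compound 3 would give in a more extended measurement. Also open, from the compounds shown here alone, is how other groups on the same aromatic carbon, such as a methoxy group, a nitrile or an amine, would read in this assay, and whether any of them would give a number rather than a limit.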